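Phenol in Place of Bromophenyl: Expecting Another Limit

A few compounds are considered here, and "the series" means these few. Any claim that something is new, unique, unknown or untested is made for them only; others in the source may bear on it.

Compound 3 `Fc1cccc(-c2nc(Nc3ccccc3Br)c3cc(F)ccc3n2)c1` belongs to a set of three compounds that share one core and differ only in the aryl group carried on a nitrogen on an aromatic ring. In a functional assay on HL-60 cells (Homo sapiens) for cytotoxicity, read by MTT assay, with a stated time of 48 h (on this read-out higher numbers stand for weaker inhibition and lower numbers for stronger inhibition), compound 3 gives > 50000 nM, which is a limit of the assay and not a measured number. Compound 1 `Fc1cccc(-c2nc(Nc3cccc(Cl)c3)c3cc(F)ccc3n2)c1` gives > 50000 nM in this assay, likewise a limit. Compound 2 `Fc1cccc(-c2nc(Nc3ccc(Br)cc3)c3cc(F)ccc3n2)c1` gives > 50000 nM in this assay, again a limit. Because every value sits at the limit of > 50000 nM in this assay, at which 3 of the 3 values shown sit, the steps a step that the two limits leave unreadable from compound 1 to compound 2, a step that the two limits leave unreadable from compound 1 to compound 3 and a step that the two limits leave unreadable from compound 2 to compound 3 have no readable size, and so compound 3 stands exactly where its two neighbours stand. Compound 4 `Oc1cccc(Nc2nc(-c3cccc(F)c3)nc3ccc(F)cc23)c1` differs from compound 3 by 3-hydroxyphenyl in place of 2-bromophenyl on a nitrogen on an aromatic ring. For the measured compounds named here, no measured step bears on this change, and the three limits give no direction for it. Compound 4 is therefore expected to show no step beyond the scatter in this assay, and a step that the limit leaves unreadable from compound 3 to compound 4 is the estimated step. Compound 4 is estimated at 60000 nM, within a range from 15000 nM to 250000 nM.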

Compound 4, half-maximal inhibitory concentration: > 50000 nM
Compound 4: a limit, no number; the forecaster's own chance of this, stated with the estimate: 70%; the middle value lies beyond the limit too.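

Compound 4 gives only a limit, as do compound 1, compound 2 and compound 3, so none of the steps linking compound 4 to the other three can be read: the limit of > 50000 nM in this assay, at which 4 of the 4 values shown sit. On these data alone, what stays open is whether any aryl group on this nitrogen of the shared core gives a measured number in this assay rather than a limit.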